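Oxolan-3-yl in Place of 1-(Methoxymethyl)propyl

This account rests on a few compounds, and the source may have more. Where it says the series, first, only, none or still open, it means among the compounds named here.

In a physicochemical assay for solubility, read by chemiluminescence (on this read-out higher numbers stand for higher solubility and lower numbers for lower solubility), compound 1 `O=C(CN(CC1CC1)C(=O)c1ccc(-c2ccccn2)cc1)Nc1cc(F)cc(F)c1` gives 25 ug/mL and compound 2 `CCC(COC)N(CC(=O)Nc1cc(F)cc(F)c1)C(=O)c1ccc(-c2ccccn2)cc1` gives 24 ug/mL so compound 2 stands level with compound 1 within the scatter. The next compound to be read is compound 3 `O=C(CN(C(=O)c1ccc(-c2ccccn2)cc1)C1CCOC1)Nc1cc(F)cc(F)c1` which is still unmeasured. The change is oxolan-3-yl in place of 1-(methoxymethyl)propyl on an amide-type nitrogen on an amide-type nitrogen, with oxolan-3-yl in place of 1-(methoxymethyl)propyl. For the measured compounds named here, only one measured step bears on it, namely a 1.0-fold lower number from compound 1 to compound 2 (0.02 log units; within the scatter) at the same nitrogen, and that step lies within the scatter. Going by the values given here, no measured compound yet carries oxolan-3-yl, so this single step is a thin guide. In this assay the expected step is a 1.2-fold higher number from compound 2 to compound 3 (0.07 log units; within the scatter) and no shift beyond the scatter is anticipated. Compound 3 is estimated at 28 ug/mL with an expected range from 12 ug/mL to 65 ug/mL on this read-out.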

Compound 3, solubility: 102 ug/mL
Compound 3: middle estimate off by 3.6-fold (0.56 log units), on the low side; measured number above the stated range.
By their numbers in this assay, from the lowest: compounds 2 and 1 (each within the scatter of the next); then compound 3.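

In this assay, the amide-type nitrogen turns out to be a place where a single change can move the number beyond the scatter, which the earlier step did not show: oxolan-3-yl in place of 1-(methoxymethyl)propyl gives a 4.3-fold higher number from compound 2 to compound 3 (0.63 log units; beyond the scatter) and oxolan-3-yl in place of cyclopropylmethyl gives a 4.1-fold higher number from compound 1 to compound 3 (0.61 log units; beyond the scatter) in the same assay. Cyclopropylmethyl and 1-(methoxymethyl)propyl stand level within the scatter, and oxolan-3-yl alone stands apart from both. Nothing measured here accounts for this rise.

The compounds shown leave open whether the rise is particular to oxolan-3-yl or would also appear with cyclopentyl, which has no ring oxygen, or with the six-membered oxan-4-yl. From the compounds shown here alone, they also differ only at this nitrogen, so whether the step holds with another group in place of the 3,5-difluorophenyl amide remains open.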